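The compounds below may be only part of what the source reports. "The series", "measured", "known", "first", "only" and "open" are said of these compounds alone.

In a functional assay on DU-145 cells (Homo sapiens) for inhibition, read by trypan blue exclusion, with a stated time of 96 h (on this read-out lower numbers stand for stronger inhibition of growth and higher numbers for weaker inhibition of growth), the measured compounds are:
Compound 1 `Cc1ccc(CS(=O)(=O)/C(=C/c2ccc(Br)cc2)C(=O)c2ccc(Cl)cc2)cc1` gives 25000 nM
Compound 2 `Cc1ccc(S/C(=C/c2ccc(F)c(C)c2)C(=O)c2ccc(Br)cc2)cc1` gives 25000 nM
Compound 3 `Cc1ccc(S/C(=C/c2ccc(Cl)c(Cl)c2)C(=O)c2ccc(Br)cc2)cc1` gives 50000 nM

Compound 3, at 50000 nM in this assay, stands within the scatter of both compound 1 and compound 2, so these three values cannot be ranked. Compound 4 `CSc1ccc(/C=C(/Sc2ccc(C)cc2)C(=O)c2ccc(Br)cc2)cc1` has not yet been measured. Its change from compound 3 is 4-(methylsulfanyl)phenyl in place of 3,4-dichlorophenyl on a double-bonded chain carbon bound to a double-bonded chain carbon and amounts to 4-(methylsulfanyl)phenyl in place of 3,4-dichlorophenyl on a double-bonded chain carbon bound to a double-bonded chain carbon. Going by the values given here, one measured step bears on this place: a 2.0-fold higher number from compound 2 to compound 3 (0.30 log units; within the scatter) puts 3,4-dichlorophenyl in place of 4-fluoro-3-methylphenyl there, and it stays within the scatter. Among the compounds with values here, that single step is thin evidence, and no measured compound carries the entering group. No step beyond the scatter is therefore expected in this assay and no direction is favoured. The expected change is a 1.7-fold lower number from compound 3 to compound 4 (0.22 log units; within the scatter) and is estimated to remain within the scatter. For compound 4 the expected range runs from 12000 nM to 70000 nM around an estimate of 30000 nM as its middle.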

Compound 4, concentration for 50% growth inhibition: 50000 nM
For compound 4 the middle estimate is 1.7-fold (0.22 log units) below the measured one; low and high end bracket the measured number.
By their numbers in this assay, from the lowest: compounds 1, 2, 3 and 4 (each within the scatter of the next).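

In this assay, 4-(methylsulfanyl)phenyl in place of 3,4-dichlorophenyl on a double-bonded chain carbon bound to a double-bonded chain carbon gives no change at the digits printed from compound 3 to compound 4 (within the scatter), and in place of 4-fluoro-3-methylphenyl it gives a 2.0-fold higher number from compound 2 to compound 4 (0.30 log units; within the scatter). Going by these compounds alone, three differently substituted phenyl groups have now been read at this place, including one that carries sulfur and no halogen, and no step among them leaves the scatter. No accompanying measurement indicates what lies behind these numbers.

The compounds shown leave open whether an amine or a carboxylic acid at this place would give a step beyond the scatter. They also leave open whether a longer chain carrying the phenyl group would do so.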